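A few compounds are considered here, and "the series" means these few. Any claim that something is new, unique, unknown or untested is made for them only; others in the source may bear on it.

Compound 1 `Cc1cc(NC(=O)Nc2ccccc2OC(F)(F)F)c2ccccc2n1` was tested in an ADME assay on HepG2 cells (Homo sapiens) for cytotoxicity, with a stated time of 72 h; on this read-out lower numbers stand for an effect already at smaller amounts and higher numbers for an effect only at larger amounts of compound. Compound 1 gives > 25000 nM there, which is a limit of the assay and not a number. Compound 2 `Cc1cc(NC(=O)Nc2cccc(N(C)C)c2)c2ccccc2n1` shares the core of compound 1 but carries a different substituent. Compound 2 gives > 25000 nM, which is likewise a limit. Compound 1 therefore stands at the limit of > 25000 nM in this assay, at which 2 of the 2 values shown sit, and its position is known only as a limit.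

Compound 3 `COc1ccccc1NC(=O)Nc1cc(C)nc2ccccc12` has not yet been measured. It differs from compound 1 in a single place: methyl in place of trifluoromethyl on an oxygen on an aromatic ring. In words, this is methyl in place of trifluoromethyl on an oxygen on an aromatic ring, or trifluoromethoxy to methoxy. For the measured compounds named here, no measured pair of compounds shows what this change does in this assay.

Since compound 1 sits at the limit of > 25000 nM in this assay, at which 2 of the 2 values shown sit, no step beyond the scatter is expected, and neither direction is favoured. The estimated change, a step that the limit leaves unreadable from compound 1 to compound 3, is expected to stay within the scatter. For compound 3 the expected value is 30000 nM, with an estimated range from 12000 nM to 60000 nM.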

Compound 3, half-maximal effective concentration: > 25000 nM
Compound 3 gave a limit, no number; the forecaster's own chance of this, stated with the estimate: 75%; the middle value does not contradict the limit.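

In this assay compound 3 gives > 25000 nM as a limit of the assay and not a number. For the compounds shown here, compound 1 also stands at a limit, so no step between compound 1 and compound 3 can be read. The compounds shown leave open what trifluoromethoxy to methoxy does in this assay and where any of their true values lies: the limit of > 25000 nM in this assay, at which 3 of the 3 values shown sit.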